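Extending the chain on compound 3

This account rests on a few compounds, and the source may have more. Where it says the series, first, only, none or still open, it means among the compounds named here.

- compound 1 `CCCCCCCCCCNC(=O)[C@@H]1CSC(c2cc(OC)c(OC)c(OC)c2)N1`: 14500 nM
- compound 2 `CCCCCCCCCCCCCCNC(=O)[C@@H]1CSC(c2cc(OC)c(OC)c(OC)c2)N1`: 2000 nM
- compound 3 `CCCCCCCCCCNC(=O)[C@@H]1CSC(c2ccc(OC)c(OC)c2)N1`: 11900 nM

In a functional assay on cells (Homo sapiens) for antiproliferative activity, read by sulforhodamine B assay, with a stated time of 48 h (a lower number here means a stronger inhibitor, a higher number a weaker inhibitor), compound 3 gives 11900 nM, the middle of the three numbers. It cannot be separated from compound 1, as the measured step is a 1.2-fold lower number from compound 1 to compound 3 (0.09 log units; within the scatter). Compound 2 stands clearly lower than both.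

The unmeasured compound 4 `CCCCCCCCCCCCCCNC(=O)[C@@H]1CSC(c2ccc(OC)c(OC)c2)N1` differs from compound 3 in one place: butyl in place of hydrogen on a saturated chain carbon, ten or more bonds along the chain from an amide-type nitrogen.

The same change has been measured once, as a 7.3-fold lower number from compound 1 to compound 2 (0.86 log units; beyond the scatter). That step was taken on the core of compound 1, which carries one more methoxy than compound 3. For the measured compounds named here, the step of a 1.2-fold lower number from compound 1 to compound 3 (0.09 log units; within the scatter) gives no sign that this methoxy matters here, though no second example confirms the transfer. A lower number of similar size is therefore expected in this assay.

The expected change is a 7.0-fold lower number from compound 3 to compound 4 (0.85 log units; beyond the scatter).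

Compound 4 is estimated at 1700 nM, with an expected range of 800 nM to 3600 nM.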

Compound 4, half-maximal inhibitory concentration: 1500 nM
For compound 4 the middle estimate is 1.1-fold (0.05 log units) above the measured one; low and high end bracket the measured number.
By their numbers in this assay, from the lowest: compounds 4 and 2 (each within the scatter of the next); then compounds 3 and 1 (each within the scatter of the next).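

In this assay, butyl in place of hydrogen on a saturated chain carbon, ten or more bonds along the chain from an amide-type nitrogen, gives a 7.9-fold lower number from compound 3 to compound 4 (0.90 log units; beyond the scatter), so the change now holds on a second core and its size carries over: the same change on two cores in this assay, a 7.3-fold lower number (0.86 log units; beyond the scatter) from compound 1 to compound 2 and a 7.9-fold lower number (0.90 log units; beyond the scatter) from compound 3 to compound 4, 1.1-fold (0.04 log units) apart, within the scatter of two such steps. The methoxy, earlier compared only on the chain of compound 1 and compound 3, can now be compared on the butyl-extended chain as well, where hydrogen in its place gives a 1.3-fold lower number from compound 2 to compound 4 (0.12 log units; within the scatter), again with no separable effect: the same change on two cores in this assay, a 1.2-fold lower number (0.09 log units; within the scatter) from compound 1 to compound 3 and a 1.3-fold lower number (0.12 log units; within the scatter) from compound 2 to compound 4, 1.1-fold (0.04 log units) apart, within the scatter of two such steps. Across these four compounds, the chain change alone moves the number beyond the scatter, whichever core carries it.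

The compounds shown leave open whether a longer chain would lower the number further, and whether an amine or a carboxylic acid in place of butyl would keep the step. They also leave open whether the step would hold with hydroxy in place of methoxy on the core.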